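The compounds below may be only part of what the source reports. "The series", "measured", "known", "first", "only" and "open" are said of these compounds alone.

Working notes on the series.

Within the data shown here, compound 1 `Cc1oc(-c2ccc(F)cc2)nc1CN1CCC(C(=O)NCCCN2C[C@H](C)C[C@H](C)C2)CC1` gives "not determined" (no result reported) in a physicochemical assay for permeability, using PAMPA; on this read-out lower numbers stand for lower permeability and higher numbers for higher permeability: no result was reported for it, so it gives no anchor for the step that follows. Among the measured compounds shown here, the only measured point in this assay is compound 2 `Cc1ccccc1-c1nc(CN2CCC(C(=O)N3CCN(CCN(C)C)CC3)CC2)c(C)o1`, which gives 14 10^-6 cm/s in this assay; compound 2 and compound 1 share the core but differ in more than one place, so no step between them is counted here, and their values cannot be compared because compound 1 has none.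

Compound 3 `Cc1ccc(-c2nc(CN3CCC(C(=O)NCCCN4C[C@H](C)C[C@H](C)C4)CC3)c(C)o2)cc1C` differs from compound 1 in a single place: 3,4-dimethylphenyl in place of 4-fluorophenyl on an aromatic carbon. Since compound 1 is without a number, the size and direction of the step to compound 3 in this assay cannot be set from the data, and any expectation rests on compound 2 alone.

Compound 3 is expected to come out near compound 2 in this assay, at an estimated 12 10^-6 cm/s, with a range from 4 10^-6 cm/s to 30 10^-6 cm/s. The measurement of compound 3 will show where it actually stands.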

Compound 3, apparent permeability: 219 10^-6 cm/s
For compound 3 the middle estimate is 18-fold (1.26 log units) below the measured one, outside the stated range (above it).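

In this assay, among these compounds, compound 1 stands at "not determined" (no result reported), so no step from it to compound 3 can be read. The compounds shown leave open how far, and in which direction, 3,4-dimethylphenyl in place of 4-fluorophenyl moves this read-out. No measured property at hand bears on the value of compound 3.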